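Methoxy for hydroxy on the cyclohexyl of compound 2

This account rests on a few compounds, and the source may have more. Where it says the series, first, only, none or still open, it means among the compounds named here.

Measured so far in an ADME assay on S9 fraction from liver (Homo sapiens) for metabolic stability, with a stated time of 1 h; on this read-out lower numbers stand for a less stable compound and higher numbers for a more stable compound:
- compound 1 `N#Cc1cnc(NCc2cnccc2C(F)(F)F)cc1NC[C@H]1C[C@@H](O)C1` gives 84%
- compound 2 `N#Cc1cnc(NCc2cnccc2C(F)(F)F)cc1N[C@H]1CC[C@H](O)CC1` gives 30%

Compound 2 holds the lower of these two numbers. The next structure, compound 3 `CO[C@H]1CC[C@@H](Nc2cc(NCc3cnccc3C(F)(F)F)ncc2C#N)CC1`, has 4-methoxycyclohexyl in place of 4-hydroxycyclohexyl on a nitrogen on an aromatic ring.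

For the measured compounds named here, only one measured step bears on this change: a number 54 percentage points lower from compound 1 to compound 2 (beyond the scatter). That large step came from swapping (3-hydroxycyclobutyl)methyl for 4-hydroxycyclohexyl at the same nitrogen, so the group there can matter in this assay. Both compounds keep their hydroxy group, however, so the step does not show what replacing it does. No step beyond the scatter is therefore expected, and the uncertainty is wide.

The estimated step is a number 5 percentage points lower from compound 2 to compound 3 (within the scatter). Compound 3 is expected at 25%, within a range from 8% to 50%.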

Compound 3, percent of the compound remaining: 19%
Compound 3: the middle estimate sits 6 percentage points above what was measured; the measured number falls inside the stated range.
By their numbers in this assay, from the lowest: compound 3; then compound 2; then compound 1.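

For the compounds shown here, the change to 4-methoxycyclohexyl gives the first direct reading of the hydroxy group at this position: in this assay there is a number 11 percentage points lower from compound 2 to compound 3 (beyond the scatter), so removing the free hydroxy does not raise the number here. The wider comparison gives a number 65 percentage points lower from compound 1 to compound 3 (beyond the scatter), and both compounds with a cyclohexyl on this nitrogen therefore stay far below the compound carrying (3-hydroxycyclobutyl)methyl, whether that cyclohexyl has a hydroxy or a methoxy. No measurement here explains either step.

Going by these compounds, it remains open whether a methoxy on the cyclobutyl ring of compound 1 would also give a lower number. Also unresolved is whether an amine in place of the oxygen, or a plain cyclohexyl with no oxygen at all, would move the number in either direction.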